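Moving a Fluorine on the Sulfonyl Aryl Ring

The source may report more compounds than this note shows. Statements on the series, on what has been measured and on what is new or still open speak of the compounds shown alone.

Three sulfonamides sharing one core were tested in an assay on cells for inhibition of HSP60/HSP10 (Homo sapiens), with a stated time of 60 min; on this read-out higher numbers stand for weaker inhibition and lower numbers for stronger inhibition. Compound 1 `COc1ccc(S(=O)(=O)Nc2ccc(-c3nc4ccccc4o3)cc2)cc1` carries a 4-methoxyphenyl on the sulfonyl sulfur, and in this assay compound 1 reaches only the limit of > 100000 nM. Compound 2 `COc1ccc(Cl)cc1S(=O)(=O)Nc1ccc(-c2nc3ccccc3o2)cc1` bears a 5-chloro-2-methoxyphenyl on that sulfur, and in this assay compound 2 likewise stops at the limit of > 100000 nM. Compound 3 `O=S(=O)(Nc1ccc(-c2nc3ccccc3o2)cc1)c1ccccc1F` has a 2-fluorophenyl on the sulfonyl sulfur, and in this assay compound 3 also returns only the limit of > 100000 nM. Because every value rests at the limit of > 100000 nM in this assay, at which 3 of the 3 values shown sit, none of the steps between them can be read: a step that the two limits leave unreadable from compound 1 to compound 2, a step that the two limits leave unreadable from compound 1 to compound 3 and a step that the two limits leave unreadable from compound 2 to compound 3 are all of unreadable size. Compound 3 therefore stands with its companions, at a limit rather than at a number.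

Compound 4 `O=S(=O)(Nc1ccc(-c2nc3ccccc3o2)cc1)c1ccc(F)cc1` differs from compound 3 only in 4-fluorophenyl in place of 2-fluorophenyl on a sulfonyl sulfur. Within the data shown here, no measured step has a readable size, so none gives a direction to expect. The closest comparison is compound 1, whose 4-methoxyphenyl on the same sulfur gave only the limit of > 100000 nM. The step expected in this assay, a step that the limit leaves unreadable from compound 3 to compound 4, is accordingly none beyond the scatter. Compound 4 is expected to stay at the limit, estimated at 200000 nM with a range from 50000 nM to 1000000 nM.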

Compound 4, half-maximal inhibitory concentration: 73000 nM
Compound 4: middle estimate off by 2.7-fold (0.44 log units), on the high side; the range from low to high includes it.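

Among these compounds, with 4-fluorophenyl in place of 2-fluorophenyl on the sulfonyl sulfur, this assay yields its only actual number in this set: compound 4 gives 73000 nM. Every other value shown is a limit of the assay. This change reads as an at least 1.3-fold lower number from compound 3 to compound 4 (0.13 log units; that floor lies within the scatter), while the comparisons with the other two groups read as an at least 1.3-fold lower number from compound 2 to compound 4 (0.13 log units; that floor lies within the scatter) and an at least 1.3-fold lower number from compound 1 to compound 4 (0.13 log units; that floor lies within the scatter), so the position can now return a number, but no step is shown to exceed the scatter. The steps among compound 1, compound 2 and compound 3 still cannot be read, and each step to compound 4 gives only a floor, because those three compounds all rest at a limit: the limit of > 100000 nM in this assay, at which 3 of the 4 values shown sit.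

As far as these compounds go, the true size of the change from 2-fluorophenyl to 4-fluorophenyl therefore remains open, as does whether any group on this ring could give a step clearly beyond the scatter. The compounds shown also leave open how this assay would respond to an amine, a carboxylic acid or a longer chain in place of the fluorine of compound 4.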